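Swapping furan-2-yl for thiophen-3-yl at the assay limit

The source may hold more compounds than are shown below. What is called first, only, known or untested is meant among the compounds shown, and "the series" means these compounds.

- compound 1 `CN(C)c1ncnc2c1c(-c1ccsc1)cn2[C@@H]1O[C@H](CO)[C@@H](O)[C@H]1O` gives > 20000 nM
- compound 2 `Nc1nc(N)c2c(-c3ccco3)cn([C@@H]3O[C@H](CO)[C@@H](O)[C@H]3O)c2n1` gives > 20000 nM
- compound 3 `Cc1nc(N)c2c(-c3ccco3)cn([C@@H]3O[C@H](CO)[C@@H](O)[C@H]3O)c2n1` gives > 20000 nM

All three results come from a functional assay on K562 cells (Homo sapiens), read by MTT assay, with a stated time of 72 h (on this read-out higher numbers stand for weaker inhibition and lower numbers for stronger inhibition), and none of them is an exact number. As far as these compounds go, compound 3 has only a limit, > 20000 nM, and so its true position is unknown. The same holds across the series, which shows (the limit of > 20000 nM in this assay, at which 3 of the 3 values shown sit).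

Compound 4 `Cc1nc(N)c2c(-c3ccsc3)cn([C@@H]3O[C@H](CO)[C@@H](O)[C@H]3O)c2n1` keeps the rest of compound 3 and changes one group, with thiophen-3-yl in place of furan-2-yl on an aromatic carbon.

Among the measured compounds shown here, the only measured step is a step that the two limits leave unreadable from compound 2 to compound 3. It concerns a different place in the structure and gives no size to carry over. For the measured compounds named here, no measured step covers this exchange of rings directly. Compound 1 also bears thiophen-3-yl on a differently substituted core, and its limit is > 20000 nM. That result offers no sign that this group brings measurable inhibition in this assay.

The expected change is therefore none beyond the scatter, in neither direction, and the estimated step is a step that the limit leaves unreadable from compound 3 to compound 4. Compound 4 is expected to give about 25000 nM, most likely reported only as a limit. For compound 4 the estimated range runs from 9000 nM to 70000 nM.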

Compound 4, half-maximal inhibitory concentration: > 20000 nM
Compound 4 gave a limit, no number; the forecaster's own chance of this, stated with the estimate: 80%; the middle value lies beyond the limit too.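

Compound 3 and compound 4 both give only limits in this assay, and no step between them can be read: the limit of > 20000 nM in this assay, at which 4 of the 4 values shown sit.

The compounds shown leave open how far each true value lies from that limit, whether thiophen-3-yl and furan-2-yl differ at all here, and which structural change, if any, would bring a measurable value in this assay.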